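Swapping the Chain Amine for a Triazole on a Weak Imide

The source may hold more compounds than are shown below. What is called first, only, known or untested is meant among the compounds shown, and "the series" means these compounds.

Compound 1 `CN(C)CCCn1nc(C2=C(c3cn(C)c4ccccc34)C(=O)NC2=O)c2cccnc21` is the weakest of the three compounds measured here. In a functional assay on K562 cells (Homo sapiens) for antiproliferative activity, read by MTT assay, with a stated time of 48 h (on this read-out lower numbers stand for stronger inhibition and higher numbers for weaker inhibition), compound 1 gives 50400 nM, the highest of the three numbers. Compound 2 `CN(C)CCCn1nc(C2=C(c3cn(C)c4ccccc34)C(=O)N(c3ccccc3)C2=O)c2cccnc21` differs from it only by a phenyl in place of hydrogen on the ring nitrogen of the imide, and in this assay compound 2 gives 1700 nM; the step of a 30-fold lower number from compound 1 to compound 2 (1.47 log units; beyond the scatter) is large. Compound 3 `Cn1cc(C2=C(c3nn(CCCN4CCCCC4)c4ncccc34)C(=O)N(c3ccccc3)C2=O)c2ccccc21` keeps the phenyl and changes the end of the chain, and compound 3 gives 3790 nM; that step, a 2.2-fold higher number from compound 2 to compound 3 (0.35 log units; beyond the scatter), is modest.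

Compound 4 `Cn1cc(C2=C(c3nn(CCCn4cncn4)c4ncccc34)C(=O)NC2=O)c2ccccc21` keeps the unsubstituted imide of compound 1 and changes only the chain terminus: 1H-1,2,4-triazol-1-yl in place of dimethylamino on a saturated chain carbon, three bonds along the chain from an aromatic nitrogen. Among the compounds with values here, the only measured step that touches the same place is the one from compound 2 to compound 3, where exchanging one amine for another moved the number only modestly, and the change in compound 4 goes further, to an aromatic ring. Within the data shown here, no measured pair separates the effect of that ring from the effect of the chain amine, so compound 4 is expected to stay near compound 1, with a step of a 1.2-fold higher number from compound 1 to compound 4 (0.08 log units; within the scatter) that could fall either side of the scatter. Compound 4 is therefore estimated at 60000 nM, within 20000 nM to 150000 nM.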

Compound 4, half-maximal inhibitory concentration: > 100000 nM
Compound 4 ended at the assay's limit; the forecaster's own chance of this, stated with the estimate: 20%; at least 1.6-fold (0.22 log units) between middle value and limit.
By their numbers in this assay, from the lowest: compound 2; then compound 3; then compound 1. At a limit, above all of these: compound 4.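

In this assay compound 4 reads > 100000 nM, which is a limit of the assay and not a number: the limit of > 100000 nM in this assay, at which 1 of the 4 values shown sits. The step is an at least 1.9-fold higher number from compound 1 to compound 4 (0.29 log units; that floor lies within the scatter), so only a floor is known, and that floor does not by itself set the two compounds apart. Even so, this is the only reading shown for a change at the chain end on the unsubstituted imide and the only one with an aromatic ring in place of an amine, and it shows that 1H-1,2,4-triazol-1-yl brings no lower number there, whereas the earlier amine exchange on the phenyl imide gave a 2.2-fold higher number from compound 2 to compound 3 (0.35 log units; beyond the scatter).

As far as these compounds go, whether the phenyl on the imide nitrogen, which gave a 30-fold lower number from compound 1 to compound 2 (1.47 log units; beyond the scatter), would also lower the number for a compound carrying 3-(1H-1,2,4-triazol-1-yl)propyl remains open. Also open, from the compounds shown here alone, is how a morpholine, an imidazole or a carboxylic acid at the chain end, or a longer chain, would read, and so whether the loss of the amine or the arrival of the triazole matters more at this position.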